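A few compounds are considered here, and "the series" means these few. Any claim that something is new, unique, unknown or untested is made for them only; others in the source may bear on it.

Of the compounds shown here, three sharing one core have been measured in a functional assay on MV4-11 cells (Homo sapiens) for inhibition, read by resazurin assay, with a stated time of 72 h; a lower number here means a stronger inhibitor of growth, a higher number a weaker inhibitor of growth. Compound 1 (`O=C1NCCC12CCN(c1c(Cl)cncc1-c1cccs1)CC2`), with a thiophen-2-yl group, gives 480 nM. Compound 2 (`O=Cc1ccc(-c2cncc(Cl)c2N2CCC3(CCNC3=O)CC2)o1`), with a 5-formylfuran-2-yl group, gives 5190 nM. Compound 3 (`Cc1ccsc1-c1cncc(Cl)c1N1CCC2(CCNC2=O)CC1`), with a 3-methylthiophen-2-yl group, gives 910 nM. Its standing among the three shows in two steps: a 1.9-fold higher number from compound 1 to compound 3 (0.28 log units; within the scatter), and a 5.7-fold lower number from compound 2 to compound 3 (0.76 log units; beyond the scatter).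

Compound 4 (`CC(=O)c1ccc(-c2cncc(Cl)c2N2CCC3(CCNC3=O)CC2)s1`) has not yet been measured. It replaces the 3-methylthiophen-2-yl group with a 5-acetylthiophen-2-yl group on the same aromatic carbon: 5-acetylthiophen-2-yl in place of 3-methylthiophen-2-yl on an aromatic carbon. Within the data shown here, no measured compound carries this group, so the evidence is indirect. The methyl group made little measurable difference in the step to compound 3, so losing it should matter little by itself. Among the measured compounds shown here, the nearest precedent is the carbonyl-bearing group of compound 2, which showed an 11-fold higher number from compound 1 to compound 2 (1.03 log units; beyond the scatter). That step also exchanged thiophene for furan, so the data cannot separate the two changes, and only part of its size should carry over. The expected result in this assay is a 2.2-fold higher number from compound 3 to compound 4 (0.34 log units; beyond the scatter), a modest move towards weaker growth inhibition. For compound 4 the estimated value is 2000 nM, with an expected range from 700 nM to 6000 nM.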

Compound 4, concentration for 50% growth inhibition: 1440 nM
The estimate for compound 4 lay 1.4-fold (0.14 log units) above the measured number, within the range that was stated.
By their numbers in this assay, from the lowest: compounds 1, 3 and 4 (each within the scatter of the next, the first and the last beyond it); then compound 2.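

At this position, two atoms from the ring nitrogen, a thiophene can carry a carbonyl-bearing group at a measurable but limited cost in this assay: acetyl in place of hydrogen gives a 3.0-fold higher number from compound 1 to compound 4 (0.48 log units; beyond the scatter) and this is a smaller step than an 11-fold higher number from compound 1 to compound 2 (1.03 log units; beyond the scatter) with the 5-formylfuran-2-yl group. Exchanging 3-methylthiophen-2-yl for 5-acetylthiophen-2-yl gives a 1.6-fold higher number from compound 3 to compound 4 (0.20 log units; within the scatter) and so leaves the two groups indistinguishable here, while exchanging 5-formylfuran-2-yl for 5-acetylthiophen-2-yl gives a 3.6-fold lower number from compound 2 to compound 4 (0.56 log units; beyond the scatter) and shows that a carbonyl on the five-membered ring does not by itself bring the full loss seen with compound 2. No measurement is available that explains these differences.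

The compounds shown cannot separate the contribution of the furan ring from that of the formyl group in compound 2, since both differ in every step to it. Also open, as far as these compounds go, is how this position responds to other kinds of group on the thiophene, such as an aminomethyl group, a carboxylic acid or a longer chain in place of the acetyl.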